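This account rests on a few compounds, and the source may have more. Where it says the series, first, only, none or still open, it means among the compounds named here.

- compound 1 `N#Cc1cn([C@@H]2O[C@H](CO)[C@@H](O)[C@@H]2N=[N+]=[N-])c2ncnc(N)c12`: 55000 nM
- compound 2 `N#Cc1cn([C@@H]2O[C@H](CO)[C@@H](O)[C@@H]2N)c2ncnc(N)c12`: > 100000 nM
- compound 3 `[N-]=[N+]=N[C@H]1[C@H](O)[C@@H](CO)O[C@H]1n1cc(C(N)=O)c2c(N)ncnc21`: not yet measured

For the measured compounds named here, in a functional assay on HFF cells (Homo sapiens) for cytotoxicity (on this read-out lower numbers stand for stronger inhibition and higher numbers for weaker inhibition), compound 1 gives 55000 nM, the only true number so far. Compound 2 reaches only a limit of the assay, > 100000 nM, as the limit of > 100000 nM in this assay, at which 1 of the 2 values shown sits, records. Compound 3 carries carbamoyl in place of cyano on an aromatic carbon. Going by the values given here, the one measured step, an at least 1.8-fold higher number from compound 1 to compound 2 (0.25 log units; that floor lies within the scatter), lies at a saturated ring carbon, so it bears only weakly on this change. No step beyond the scatter is therefore expected in this assay, and the expected step is a 1.1-fold lower number from compound 1 to compound 3 (0.04 log units; within the scatter). For compound 3 the estimated value is 50000 nM, with an expected range of 15000 nM to 100000 nM.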

Compound 3, half-maximal inhibitory concentration: 66000 nM
For compound 3 the middle estimate is 1.3-fold (0.12 log units) below the measured one; low and high end bracket the measured number.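

Carbamoyl in place of cyano on an aromatic carbon gives a 1.2-fold higher number from compound 1 to compound 3 (0.08 log units; within the scatter) in this assay and so no readable difference, although carbamoyl brings a hydrogen-bond donor that cyano lacks. For the compounds shown here, this is the first step read on the five-membered aromatic ring, since the earlier step lay at a saturated ring carbon. Compound 2 remains a limit: the limit of > 100000 nM in this assay, at which 1 of the 3 values shown sits.

Going by these compounds, a carboxylic acid or an aminomethyl group on this aromatic carbon remains open. So does the pairing of carbamoyl with amino in place of azido on the saturated ring carbon.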